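Replacing Methylsulfonyl with Phenylcarbamoyl on the Amine Nitrogen

The source may report more compounds than this note shows. Statements on the series, on what has been measured and on what is new or still open speak of the compounds shown alone.

Of the compounds shown here, three sharing one core have been measured in a functional assay on the whole organism (artery) for inhibition, with Rattus norvegicus as the target, at a dose of 3 mg/kg by the intraduodenal route; a lower number here means less inhibition, a higher number more inhibition at the dose given (going by the name of the read-out). Compound 1 `CCCCc1ccc(CN(C(C)C)S(C)(=O)=O)c(=O)n1Cc1ccc(-c2ccccc2-c2nn[nH]n2)cc1` gives 82.7%, compound 2 `CCCCc1ccc(CNC(=O)OC(C)(C)C)c(=O)n1Cc1ccc(-c2ccccc2-c2nn[nH]n2)cc1` gives 68.9%, and compound 3 `CCCCc1ccc(CNS(C)(=O)=O)c(=O)n1Cc1ccc(-c2ccccc2-c2nn[nH]n2)cc1` gives 54.8%. Compound 3 therefore stands lowest of the three, with compound 2 nearest and compound 1 furthest, and both of those gaps exceed the usual scatter.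

The unmeasured compound 4 `CCCCc1ccc(CNC(=O)Nc2ccccc2)c(=O)n1Cc1ccc(-c2ccccc2-c2nn[nH]n2)cc1` differs from compound 3 in one place: phenylcarbamoyl in place of methylsulfonyl on an amine nitrogen.

Among the compounds with values here, two measured steps bear on this. The step of a number 14.1 percentage points lower from compound 2 to compound 3 (beyond the scatter) shows that, at this same amine nitrogen, a carbonyl-bearing group rather than methylsulfonyl went with a higher number. The step of a number 27.9 percentage points lower from compound 1 to compound 3 (beyond the scatter) shows that a larger group on that nitrogen also went with a higher number. Within the data shown here, the phenylcarbamoyl group both carries a carbonyl and brings more heavy atoms than methylsulfonyl, so a rise beyond the scatter is expected in this assay, though no measured step matches a phenyl-bearing group directly, which widens the range. The expected step is a number 17.2 percentage points higher from compound 3 to compound 4 (beyond the scatter). Compound 4 is estimated at 72%, within a range from 55% to 88%.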

Compound 4, a percentage reported as inhibition, in the whole organism at one dose (the size of the read-out at that dose, not a potency): 0%
For compound 4 the middle estimate is 72 percentage points above the measured one, and the stated range ends above it.
By their numbers in this assay, from the lowest: compound 4; then compound 3; then compound 2; then compound 1.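

Having a carbonyl on this amine nitrogen does not by itself go with a high number: in this assay, anilino in place of tert-butoxy on the carbonyl carbon gives a number 68.9 percentage points lower from compound 2 to compound 4 (beyond the scatter), so what is attached to that carbonyl matters greatly. Adding heavy atoms on this nitrogen does not by itself go with a high number either, since phenylcarbamoyl in place of methylsulfonyl gives a number 54.8 percentage points lower from compound 3 to compound 4 (beyond the scatter), and (phenylcarbamoyl)amino in place of isopropyl(methylsulfonyl)amino on the saturated chain carbon gives a number 82.7 percentage points lower from compound 1 to compound 4 (beyond the scatter), which leaves compound 4 against the trend suggested by compound 1 and compound 3. No measurement available here accounts for this fall.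

Going by these compounds, it remains open whether the loss goes with the phenyl ring or with the added nitrogen and its hydrogen, a question that methylcarbamoyl, which keeps that nitrogen without the ring, and benzoyl, which keeps the ring without that nitrogen, could help to separate. A reading at one dose also leaves open whether compound 4 would show any inhibition at a higher dose.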